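The source may report more compounds than this note shows. Statements on the series, on what has been measured and on what is new or still open speak of the compounds shown alone.

Measured so far in a functional assay on B16-F10 cells (Mus musculus) for cytotoxicity; a lower number here means a stronger inhibitor, a higher number a weaker inhibitor:
- Compound 1 `O=c1oc2ccccc2c2nc3c(ccc4cc[nH]c43)c(-c3ccc(Br)cc3)c12` gives 70700 nM
- Compound 2 `O=c1oc2ccccc2c2nc3c(ccc4cc[nH]c43)c(-c3ccc(Cl)cc3Cl)c12` gives 70700 nM
- Compound 3 `O=c1oc2ccccc2c2nc3c(ccc4cc[nH]c43)c(-c3ccccc3Br)c12` gives 70700 nM

Compound 3 stands level with compound 1 and compound 2 at the digits shown. The next compound, compound 4 `O=c1oc2ccccc2c2nc3c(ccc4cc[nH]c43)c(-c3ccc(Cl)cc3)c12`, carries 4-chlorophenyl in place of 2-bromophenyl on an aromatic carbon. Going by the values given here, three measured steps bear on this change, all swaps of the same aryl group. Exchanging 4-bromophenyl for 2-bromophenyl gave no change at the digits printed from compound 1 to compound 3 (within the scatter). Exchanging 4-bromophenyl for 2,4-dichlorophenyl gave no change at the digits printed from compound 1 to compound 2 (within the scatter). Exchanging 2,4-dichlorophenyl for 2-bromophenyl gave no change at the digits printed from compound 2 to compound 3 (within the scatter). None of the three compounds carries 4-chlorophenyl itself, so this remains an extrapolation. The expected result in this assay is no change at the digits printed from compound 3 to compound 4 (within the scatter), with no shift beyond the scatter in either direction. For compound 4 the estimate is 70700 nM, with an expected range from 40000 nM to 100000 nM.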

Compound 4, half-maximal inhibitory concentration: 70700 nM
For compound 4 middle estimate and measured number coincide at the digits printed; the range from low to high includes it.
By their numbers in this assay, from the lowest: compounds 1, 2, 3 and 4 (each within the scatter of the next).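

In this assay, 4-chlorophenyl at this position, opposite the ring nitrogen, brought no change at the digits printed from compound 3 to compound 4 (within the scatter). Hydrogen in place of chloro gave no change at the digits printed from compound 2 to compound 4 (within the scatter), and chloro in place of bromo gave no change at the digits printed from compound 1 to compound 4 (within the scatter), so two smaller edits on the aryl ring, each in one place, also leave the read-out where it stood. No measurement available here explains why these halogen changes leave the number unmoved.

From the compounds shown here alone, all four aryl groups carry halogen, so it remains open whether this position can shift the number at all. A plain phenyl, or a phenyl bearing an amine or a carboxylic acid, would test that.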